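Methoxy on the ring of compound 2

A few compounds are considered here, and "the series" means these few. Any claim that something is new, unique, unknown or untested is made for them only; others in the source may bear on it.

In an ADME assay on FM3A cells (Mus musculus) (on this read-out higher numbers stand for an effect only at larger amounts of compound and lower numbers for an effect already at smaller amounts), compound 1 (`COC12C[C@H](CC[C@@H]1C)C(C)(CI)OO2`) gives > 54000 nM as a limit and not as a number. Compound 2 (`CC1(CI)C[C@H]2CCCC(C2)OO1`) gives > 96000 nM and this too is only a limit. Compound 2 therefore has no exact position on the scale, and no order can be stated from these two readings. Compound 3 (`COC12CCC[C@H](CC(C)(CI)OO1)C2`) has methoxy in place of hydrogen on a saturated ring carbon, two ring bonds from the ring atom that bears a fused ring methoxy in place of hydrogen on a saturated ring carbon in its difference from compound 2. For the measured compounds named here, no measured step yet sizes such a change. The expected step of an at least 1.2-fold lower number from compound 2 to compound 3 (0.10 log units; that floor lies within the scatter) is none beyond the usual scatter in this assay and has no firm direction. For compound 3 the estimate is 75000 nM with an expected range from 30000 nM to 150000 nM and another limit is the likeliest report.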

Compound 3, half-maximal effective concentration: > 80000 nM
Compound 3 ended at the assay's limit; the forecaster's own chance of this, stated with the estimate: 75%; at least 1.0-fold (0.02 log units) between middle value and limit.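

Compound 2 and compound 3 both stand only as limits in this assay, so no step can be read for methoxy in place of hydrogen on a saturated ring carbon. From the compounds shown here alone, whether this change shifts the read-out, in either direction or by any size, stays open.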